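Replacing a dichlorophenyl by a nitrophenyl on the shared core

The source may report more compounds than this note shows. Statements on the series, on what has been measured and on what is new or still open speak of the compounds shown alone.

Among the compounds with values here, the two compounds measured so far share one core and differ only in the aryl group on a saturated ring carbon. In a functional assay on Ehrlich cells (Mus musculus) for cytotoxicity, tested at 25 ug/mL (on this read-out higher numbers stand for a stronger effect at the one concentration tested and lower numbers for a weaker effect), compound 1 `COc1ccc(C2C(C#N)=C(N)N(c3cc(OC)c(OC)c(OC)c3)C3=C2C(=O)CC(C)(C)C3)cc1` gives 1%, while compound 2 `COc1cc(N2C(N)=C(C#N)C(c3ccc(Cl)cc3Cl)C3=C2CC(C)(C)CC3=O)cc(OC)c1OC` gives 55%. Within the data shown here, compound 2 thus stands highest of the two numbers in this assay, and the only step known here, a number 54 percentage points higher from compound 1 to compound 2 (beyond the scatter), is the one that separates it from compound 1.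

Compound 3 `COc1cc(N2C(N)=C(C#N)C(c3cccc([N+](=O)[O-])c3)C3=C2CC(C)(C)CC3=O)cc(OC)c1OC` is not yet measured. Its difference from compound 2 is 3-nitrophenyl in place of 2,4-dichlorophenyl on a saturated ring carbon. Among the measured compounds shown here, the one measured step bears on this change only in part: it shows that exchanging the aryl group at this position can shift the read-out by a large amount, but the 3-nitrophenyl group has no measured neighbour of its own. A step in either direction is therefore possible, and a lower number than that of compound 2 is taken as somewhat more likely. The step expected in this assay is a number 25 percentage points lower from compound 2 to compound 3 (beyond the scatter). Compound 3 is accordingly expected to give about 30%, within a range from 3% to 60%.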

Compound 3, a percentage reported as activity, at one concentration (the size of the read-out at that concentration, not a potency): 20%
Estimate against measurement, compound 3: 10 percentage points above, and the stated range covers the measured number.
By their numbers in this assay, from the lowest: compound 1; then compound 3; then compound 2.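

In this assay, exchanging the 2,4-dichlorophenyl for 3-nitrophenyl on the saturated ring carbon gives a number 35 percentage points lower from compound 2 to compound 3 (beyond the scatter), while the same group set against 4-methoxyphenyl gives a number 19 percentage points higher from compound 1 to compound 3 (beyond the scatter). The position therefore no longer appears as a contrast between two extremes: among these three compounds, each aryl group gives its own level of read-out, with 3-nitrophenyl lying between the other two and every gap beyond the usual scatter. Nothing available accounts for this order of the three aryl groups.

Each of the three aryl groups differs from the others in both its substituent and where that substituent sits on the phenyl ring, so the compounds shown do not separate these two changes; a 4-nitrophenyl or a 4-chlorophenyl group at the same carbon would bear on that question. The 3,4,5-trimethoxyphenyl group on the ring nitrogen is common to all three, which leaves open whether the same order would hold with a plain phenyl or a benzyl group in its place.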